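The source may report more compounds than this note shows. Statements on the series, on what has been measured and on what is new or still open speak of the compounds shown alone.

Compound 2 `O=C(C1=C(Nc2ccc(I)cc2)C(=O)N(CCCn2ccnc2)C1c1ccc(Br)cc1)c1ccccc1` gives 23400 nM in a functional assay on SAOS-2 cells (Homo sapiens) for antiproliferative activity, read by MTT assay, with a stated time of 72 h (on this read-out lower numbers stand for stronger inhibition and higher numbers for weaker inhibition), the lower of the two numbers obtained in this series. Within the data shown here, its only measured neighbour is compound 1 `NC1=C(C(=O)c2ccccc2)C(c2ccc(Br)cc2)N(CCCn2ccnc2)C1=O`, in which the amine nitrogen carries hydrogen instead of 4-iodophenyl; in this assay compound 1 gives 107000 nM. Among the measured compounds shown here, the single step recorded so far, a 4.6-fold lower number from compound 1 to compound 2 (0.66 log units; beyond the scatter), thus shows that placing an aryl group on that nitrogen is worth a modest gain.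

Compound 3 `O=C(C1=C(NCc2ccccc2)C(=O)N(CCCn2ccnc2)C1c1ccc(Br)cc1)c1ccccc1` takes the next step from compound 2: benzyl in place of 4-iodophenyl on an amine nitrogen. For the measured compounds named here, no measured pair in this set exchanges one carbon substituent on that nitrogen for another, so the only guide is the step from compound 1 to compound 2, which tells that the nitrogen tolerates, and even rewards, a group in place of hydrogen. Because that step was a 4.6-fold lower number from compound 1 to compound 2 (0.66 log units; beyond the scatter), compound 3 is expected to keep a substituted nitrogen's advantage over compound 1, though whether benzyl matches 4-iodophenyl is open. For compound 3 the expected step is a 1.5-fold higher number from compound 2 to compound 3 (0.17 log units; within the scatter), a small loss within or near the scatter. The estimate for compound 3 in this assay is therefore 35000 nM, with a range from 12000 nM to 100000 nM.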

Compound 3, half-maximal inhibitory concentration: 31600 nM
Estimate against measurement, compound 3: 1.1-fold (0.04 log units) above, within the range that was stated.
By their numbers in this assay, from the lowest: compounds 2 and 3 (each within the scatter of the next); then compound 1.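

In this assay, the exchange of 4-iodophenyl for benzyl gives a 1.4-fold higher number from compound 2 to compound 3 (0.13 log units; within the scatter), so compound 2 and compound 3 cannot be told apart on this read-out, even though iodine leaves and the entering group holds carbon only. The second step, a 3.4-fold lower number from compound 1 to compound 3 (0.53 log units; beyond the scatter), shows that the gain over the unsubstituted amine is not tied to 4-iodophenyl: on this amine nitrogen, a second and different substituent carrying an aromatic ring also lies beyond the scatter from compound 1. The compounds shown offer no measurement that accounts for why these two groups read alike.

Going by these compounds, whether the gain requires an aromatic ring at all remains open, and a simple alkyl chain such as butyl or a saturated ring such as cyclohexyl on this nitrogen would address that question. On these data alone, it is also open what the iodine contributes on its own, which plain phenyl would separate from 4-iodophenyl, and whether a substituted benzyl, such as 4-iodobenzyl, could take the number lower than those of compound 2 and compound 3.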